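Weak antiproliferative activity in two spiro compounds and a third

The source may report more compounds than this note shows. Statements on the series, on what has been measured and on what is new or still open speak of the compounds shown alone.

Measured so far:
compound 1 `Cc1ccc(-n2nncc2CN2C(=O)C3(C(C#N)=C(N)Oc4c3c3nc5ccccc5nc3c3ccccc43)c3ccccc32)cc1Cl` — > 50000 nM
compound 2 `N#CC1=C(N)Oc2c(N)cc3nc4ccccc4nc3c2C12C(=O)N(Cc1cnnn1-c1ccccc1Br)c1ccccc12` — 38000 nM

Of the compounds shown here, two have been tested in a functional assay on HepG2 cells (Homo sapiens) for antiproliferative activity, read by MTT assay, with a stated time of 48 h; on this read-out lower numbers stand for stronger inhibition and higher numbers for weaker inhibition. For compound 1 `Cc1ccc(-n2nncc2CN2C(=O)C3(C(C#N)=C(N)Oc4c3c3nc5ccccc5nc3c3ccccc43)c3ccccc32)cc1Cl` the result is a limit of the assay and not a number: compound 1 gives > 50000 nM, as the line the limit of > 50000 nM in this assay, at which 1 of the 2 values shown sits, records. Going by the values given here, compound 2 `N#CC1=C(N)Oc2c(N)cc3nc4ccccc4nc3c2C12C(=O)N(Cc1cnnn1-c1ccccc1Br)c1ccccc12` is the only compound with a number, and in this assay compound 2 gives 38000 nM. Compound 2 therefore stands as the one measured point, with the other value a limit.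

Compound 3 `N#CC1=C(N)Oc2c(N)cc3nc4ccccc4nc3c2C12C(=O)N(Cc1cnnn1-c1ccc(Cl)cc1Cl)c1ccccc12` is not yet measured. It differs from compound 2 in one place: 2,4-dichlorophenyl in place of 2-bromophenyl on an aromatic nitrogen.

Among the compounds with values here, no step between measured compounds is available to guide this change, so the size of the step from compound 2 to compound 3 is hard to foresee; the expectation is a step of no more than the usual scatter, in either direction, and the estimated step is a 1.1-fold higher number from compound 2 to compound 3 (0.02 log units; within the scatter). Compound 3 is expected to give about 40000 nM, within a range from 15000 nM to 100000 nM.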

Compound 3, half-maximal inhibitory concentration: > 50000 nM
Compound 3 ended at the assay's limit; the forecaster's own chance of this, stated with the estimate: 45%; at least 1.2-fold (0.09 log units) between middle value and limit.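

Going by these compounds alone, this is the first readable step at this position, the aromatic nitrogen of the five-membered aromatic ring with 3 nitrogen. In this assay, putting 2,4-dichlorophenyl in place of 2-bromophenyl gives an at least 1.3-fold higher number from compound 2 to compound 3 (0.11 log units; that floor lies within the scatter). That floor does not separate the change from ordinary variation between repeated measurements, but it does show that this swap of halogen-bearing rings fails to bring the number down, and how far the true value lies past the floor stays unknown, because compound 3 gives a limit of the assay and not a number: the limit of > 50000 nM in this assay, at which 2 of the 3 values shown sit.

Within the data shown here, compound 1 differs from compound 2 and compound 3 in more than one place, so no steps to it can be read, and the two rings compared here leave open whether a single change of halogen, or its place on the ring, matters at all. From the compounds shown here alone, it also remains open whether a plain phenyl ring, or a ring carrying an amine, a methoxy group or a carboxylic acid, would bring the number well down in this assay.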